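Methoxy for fluoro on the pyridyl amide substituent

This account rests on a few compounds, and the source may have more. Where it says the series, first, only, none or still open, it means among the compounds named here.

Compound 2 `O=C1c2cc(COc3ccccc3)nn2CCN1c1ccc(F)cn1` carries a 5-fluoropyridin-2-yl group on the amide-type nitrogen in the ring of the shared core. In a functional assay on HEK293 cells for positive allosteric modulation of metabotropic glutamate receptor 5 (Homo sapiens), read by calcium flux (on this read-out higher numbers stand for larger maximal responses and lower numbers for smaller maximal responses), compound 2 gives 72%. Among the measured compounds shown here, this is the lowest of the two numbers so far: compound 1 `O=C1c2cc(COc3ccccc3)nn2CCN1c1ccc(F)cc1F` gives 101%, and the step of a number 29 percentage points lower from compound 1 to compound 2 (beyond the scatter) lies beyond the scatter. Compound 3 `COc1ccc(N2CCn3nc(COc4ccccc4)cc3C2=O)nc1` is not yet measured. It differs from compound 2 in one place: methoxy in place of fluoro on an aromatic carbon, on an aromatic carbon of a six-membered aromatic ring with 1 nitrogen, two atoms from the ring nitrogen; cut one bond further out, 5-fluoropyridin-2-yl becomes 5-methoxypyridin-2-yl. For the measured compounds named here, no measured step covers this kind of change: the single step available, from compound 1 to compound 2, exchanges the whole aromatic group on the amide-type nitrogen and gives no information on substituents of a retained ring. With nothing bearing on it, the working expectation for compound 3 in this assay is a step of no change at the digits printed from compound 2 to compound 3 (within the scatter), that is, no change beyond the scatter. Compound 3 is therefore estimated at 72%, with a wide range from 50% to 95%.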

Compound 3, largest response reached (Emax), in percent of the reference or control that the assay uses: 74%
The estimate for compound 3 lay 2 percentage points below the measured number; measured number inside the range.
By their numbers in this assay, from the lowest: compounds 2 and 3 (each within the scatter of the next); then compound 1.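

In this assay, among the compounds shown here, the change from fluoro to methoxy on an aromatic carbon, two atoms from the ring nitrogen, gives the first reading for a substituent on a retained ring (a number 2 percentage points higher from compound 2 to compound 3 (within the scatter)). This position therefore tolerates methoxy, with one more heavy atom and one hydrogen-bond acceptor, without a shift beyond the scatter in maximal response. The step from the 2,4-difluorophenyl group to 5-methoxypyridin-2-yl (a number 27 percentage points lower from compound 1 to compound 3 (beyond the scatter)) is also beyond the scatter, as was the step to 5-fluoropyridin-2-yl (a number 29 percentage points lower from compound 1 to compound 2 (beyond the scatter)), so neither substituent at this position brings the pyridyl compounds within the scatter of compound 1. No independent measurement bears on the reason for this result.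

Still open, going by these compounds, is whether the position tolerates groups of other kinds, such as an amine, a nitrile or a longer alkoxy chain, or whether some of them would move the maximal response beyond the scatter in either direction. The compounds shown also leave open whether any substituent on the pyridyl ring can reach the response of compound 1.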